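Methoxy in place of hydrogen on compound 1

The compounds below may be only part of what the source reports. "The series", "measured", "known", "first", "only" and "open" are said of these compounds alone.

Measured in a functional assay on Bel7402/5-FU cells (Homo sapiens) for cytotoxicity, read by MTT assay, with a stated time of 72 h; on this read-out lower numbers stand for stronger inhibition and higher numbers for weaker inhibition:
Compound 1 `O=C1C=CCC/C1=C\C=C\c1ccccc1`: 4200 nM
Compound 2 `O=C1C=CCC/C1=C\C=C\c1ccc(F)cc1`: 1900 nM
Compound 3 `O=C1C=CCC/C1=C\C=C\c1ccc(Br)cc1`: 4300 nM

Among these three numbers, compound 1 sits in the upper part, at 4200 nM. The bromo replacement stays within the scatter, with a 1.0-fold higher number from compound 1 to compound 3 (0.01 log units; within the scatter), while the fluoro replacement goes beyond it, with a 2.2-fold lower number from compound 1 to compound 2 (0.34 log units; beyond the scatter).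

The next compound is compound 4 `COc1ccccc1/C=C/C=C1\CCC=CC1=O`, not yet measured. It carries one change to the core of compound 1: methoxy in place of hydrogen on an aromatic carbon. In words, this is methoxy in place of hydrogen on an aromatic carbon, ortho to a large group.

The two replacements on the same aromatic ring are the nearest guide. Their steps are small, and the gap between the two is also modest, with a 2.3-fold higher number from compound 2 to compound 3 (0.35 log units; beyond the scatter). For the measured compounds named here, neither brings in methoxy, and neither places a group ortho to a large group, so the data offer no direct precedent. Going by the values given here, on this basis, no step clearly beyond the scatter is expected in this assay, and no direction is firmly favoured. The estimate amounts to an expected 1.2-fold lower number from compound 1 to compound 4 (0.08 log units; within the scatter). For compound 4 the estimated value is 3500 nM, with an expected range from 1500 nM to 8000 nM.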

Compound 4, half-maximal inhibitory concentration: 2500 nM
For compound 4 the middle estimate is 1.4-fold (0.15 log units) above the measured one; the measured number falls inside the stated range.
By their numbers in this assay, from the lowest: compounds 2, 4, 1 and 3 (each within the scatter of the next, the first and the last beyond it).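

In this assay, methoxy in place of hydrogen on an aromatic carbon, ortho to a large group, gives a 1.7-fold lower number from compound 1 to compound 4 (0.23 log units; within the scatter). For the compounds shown here, this is the first information on this position, since the fluoro and bromo replacements in compound 2 and compound 3 sit elsewhere on the same aromatic ring, and it shows that a methoxy group can stand here without a step beyond the usual scatter of this read-out. Nothing available explains why this change leaves the number within the scatter of compound 1.

The compounds shown leave open whether this position would respond differently to other groups, such as an amine, a carboxylic acid or a longer ether chain like ethoxy, since a single replacement that stays within the scatter cannot show how much room for change the position has. They also leave open how methoxy would behave at the ring position held by fluoro and bromo, and how fluoro or bromo would behave at the position now held by methoxy.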